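Swapping the Aromatic Group on an Amide-Type Ring Nitrogen

The compounds below may be only part of what the source reports. "The series", "measured", "known", "first", "only" and "open" are said of these compounds alone.

Compounds measured so far in an ADME assay on HepG2 cells (Homo sapiens) for cytotoxicity; on this read-out lower numbers stand for higher toxicity in this test and higher numbers for lower toxicity in this test
Compound 1 `CSc1cccc(N2C(=O)CN(c3ccc(C(F)(F)F)cc3)CC2C(=O)NC2CCCC2)c1` gives 10000 nM
Compound 2 `COc1cccc(N2CC(=O)N(c3cccc(SC)c3)C(C(=O)NC3CCCC3)C2)c1` gives > 50000 nM
Compound 3 `CSc1cncc(N2C(=O)CN(c3cccc(C(F)(F)F)c3)CC2C(=O)NC2CCCC2)c1` gives 26000 nM

The reading for compound 2 is a limit of the assay. Of the two values that are numbers, compound 3 holds the higher with 26000 nM and stands clear of compound 1 by more than the scatter. The change to compound 4 `CC(F)(F)c1cccc(N2C(=O)CN(c3cccc(C(F)(F)F)c3)CC2C(=O)NC2CCCC2)c1` is a group of 10 heavy atoms (8 carbon, 2 fluorine; one six-membered aromatic ring of carbon only) in place of a group of 8 heavy atoms (6 carbon, 1 nitrogen, 1 sulfur; one six-membered aromatic ring with 1 hetero atom), on an amide-type nitrogen in a ring and it lies next to the ring atom that bears a cyclopentylcarbamoyl group. Within the data shown here, no measured step covers this nitrogen. Among the measured compounds shown here, the one measured step is an at least 5.0-fold higher number from compound 1 to compound 2 (0.69 log units; beyond the scatter) and it changes the group on an amine nitrogen in a ring, so it shows only that an aromatic swap elsewhere can move this assay beyond the scatter. Compound 1 has a ring of carbon only on the amide-type nitrogen and gives 10000 nM as the lower number. Compound 2 goes against any pattern here, with a ring of carbon only at that nitrogen and a limit of > 50000 nM as its reading. A small move toward a lower number is therefore expected, about the size of the scatter. The expected step is a 1.9-fold lower number from compound 3 to compound 4 (0.27 log units; within the scatter) in this estimate. The estimate for compound 4 is 14000 nM within an expected range from 6000 nM to 35000 nM as its bounds.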

Compound 4, half-maximal cytotoxic concentration: 9000 nM
Compound 4: middle estimate off by 1.6-fold (0.19 log units), on the high side, within the range that was stated.
By their numbers in this assay, from the lowest: compounds 4 and 1 (each within the scatter of the next); then compound 3. At a limit, above all of these: compound 2.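

In this assay, the swap on the amide-type nitrogen gives a 2.9-fold lower number from compound 3 to compound 4 (0.46 log units; beyond the scatter). Among these compounds, this is the first measured step at this position, and it shows that the group on this nitrogen can move the number beyond the scatter, here toward higher toxicity in this test. The earlier step changed the group on the amine nitrogen, so each ring nitrogen now has one measured step, but the two swaps involve different groups and give no shared rule. This step replaces a whole group at once, so the ring of carbon only, the two fluorines and the loss of the sulfur and the ring nitrogen all arrive together, and nothing measured here accounts for the change.

The compounds shown do not separate these parts, so it remains open whether the ring nitrogen or the sulfur-bearing chain carries the difference. Also open, on these data alone, is how the number would respond to an amine or a carboxylic acid on the aromatic ring at this amide-type nitrogen.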